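Swapping one amide group on a weak cell inhibitor

This account rests on a few compounds, and the source may have more. Where it says the series, first, only, none or still open, it means among the compounds named here.

In a functional assay on MIA PaCa-2 cells (Homo sapiens) for inhibition, read by MTT assay (on this read-out lower numbers stand for stronger inhibition and higher numbers for weaker inhibition), compound 1 (`CN(C)C(=O)c1cc2cnc(NC3CCCCC3)nc2n1C1CCCC1`) gives 25000 nM. Compound 2 (`O=C(Nc1ccc[n+]([O-])c1)c1cc2cnc(Nc3ccc(N4CCNCC4)cn3)nc2n1C1CCCC1`) gives 125000 nM, the higher of the two numbers and so the weaker inhibition. Compound 3 (`O=C(Nc1ccccc1F)c1cc2cnc(Nc3ccc(N4CCNCC4)cn3)nc2n1C1CCCC1`) differs from compound 2 in one place: a group of 7 heavy atoms (6 carbon, 1 fluorine; one six-membered aromatic ring of carbon only) in place of a group of 7 heavy atoms (5 carbon, 1 nitrogen, 1 oxygen; one six-membered aromatic ring with 1 hetero atom), on an amide-type nitrogen. Among the compounds with values here, no measured pair shows what such a swap does, so any expectation is loose. Within the data shown here, the only other measurement, compound 1 at 25000 nM, lies lower, so a drop seems the likelier direction. The expected change, a 3.1-fold lower number from compound 2 to compound 3 (0.49 log units; beyond the scatter), is a moderate drop beyond the scatter. For compound 3 the estimated value is 40000 nM, with an expected range of 8000 nM to 150000 nM.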

Compound 3, half-maximal inhibitory concentration: 3670 nM
Beside the measured number, compound 3's estimate is 11-fold (1.04 log units) above it, and the stated range ends above it.
By their numbers in this assay, from the lowest: compound 3; then compound 1; then compound 2.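

At the amide-type nitrogen, replacing the aromatic ring bearing nitrogen and oxygen with 2-fluorophenyl in this assay gives a 34-fold lower number from compound 2 to compound 3 (1.53 log units; beyond the scatter). Both groups have the same count of heavy atoms, so at this position a large change in the read-out can arise without any change in that count. The compounds offer no measurement that explains the step. The compounds shown leave open whether the fluorine or the change of ring matters more. Plain phenyl, or a pyridine ring without the oxygen, on the same nitrogen would help separate the two.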